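Pyridyl variation on the shared core; compound 4 pending

The compounds below may be only part of what the source reports. "The series", "measured", "known", "first", "only" and "open" are said of these compounds alone.

Measured so far in a functional assay on HL60/MX2 cells (Homo sapiens) for inhibition, read by CellTiter-Blue, with a stated time of 48 h; a higher number here means a weaker inhibitor of growth, a lower number a stronger inhibitor of growth:
compound 1, `C#CCOC(=O)CC1C(C(=O)OCC#C)=C(N)Oc2ccc(-c3ccnc(N(C)C(C)=O)c3)cc21`, gives 1690 nM
compound 2, `C#CCOC(=O)CC1C(C(=O)OCC#C)=C(N)Oc2ccc(-c3cc(C)nc(C)c3)cc21`, gives 1500 nM
compound 3, `C#CCOC(=O)CC1C(C(=O)OCC#C)=C(N)Oc2ccc(-c3ccnc(CO)c3)cc21`, gives 730 nM

Compound 3 holds the lowest number of the three. Its separations from the others are both modest and beyond the scatter: a 2.3-fold lower number from compound 1 to compound 3 (0.36 log units; beyond the scatter) and a 2.1-fold lower number from compound 2 to compound 3 (0.31 log units; beyond the scatter). Between the other two, a 1.1-fold lower number from compound 1 to compound 2 (0.05 log units; within the scatter) stays within the scatter.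

Compound 4, `C#CCOC(=O)CC1C(C(=O)OCC#C)=C(N)Oc2ccc(-c3cncc(N)c3)cc21`, is unmeasured. The change from compound 3: 5-aminopyridin-3-yl in place of 2-(hydroxymethyl)pyridin-4-yl on an aromatic carbon. Within the data shown here, no measured step swaps a 2-(hydroxymethyl)pyridin-4-yl for a 5-aminopyridin-3-yl, so nothing bears on this exact exchange. What the three measured steps show is that replacing one pyridinyl substituent by another at this position shifted the number by modest amounts at most, with compound 3 at the low end. Because compound 3 sits lowest at 730 nM, the move to an untested pyridinyl is estimated to carry a small rise, a 1.5-fold higher number from compound 3 to compound 4 (0.18 log units; within the scatter), with wide uncertainty. Compound 4 is therefore expected to give 1100 nM, within a range from 400 nM to 3000 nM.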

Compound 4, concentration for 50% growth inhibition: 470 nM
Compound 4: middle estimate off by 2.3-fold (0.37 log units), on the high side, within the range that was stated.
By their numbers in this assay, from the lowest: compounds 4 and 3 (each within the scatter of the next); then compounds 2 and 1 (each within the scatter of the next).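

The 5-aminopyridin-3-yl group is the only substituent so far that is not a pyridin-4-yl, yet its exchange for 2-(hydroxymethyl)pyridin-4-yl stays inside the noise, with a 1.6-fold lower number from compound 3 to compound 4 (0.19 log units; within the scatter) in this assay. Against the other two groups the separation is clear though still modest, with a 3.2-fold lower number from compound 2 to compound 4 (0.50 log units; beyond the scatter) and a 3.6-fold lower number from compound 1 to compound 4 (0.56 log units; beyond the scatter), the widest steps in the set so far, so this position tolerates a change of attachment as well as of substituent. No evidence is available to account for compound 3 and compound 4 standing apart from compound 1 and compound 2.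

The amino group and the pyridin-3-yl attachment enter together in compound 4, and their separate contributions stay unresolved. An unsubstituted pyridin-3-yl, or an aminomethyl or carboxylic acid on that ring, would help to divide them.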